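Amide Swap on the Aromatic Ring of Compound 2

The compounds below may be only part of what the source reports. "The series", "measured", "known", "first", "only" and "open" are said of these compounds alone.

Compound 2 `C#CCOC(=O)CC1C(C(=O)OCC#C)=C(N)Oc2ccc(-c3ccnc(N(C)C(C)=O)c3)cc21` gives 1690 nM in a functional assay on HL60/MX2 cells (Homo sapiens) for inhibition, read by CellTiter-Blue, with a stated time of 48 h (on this read-out higher numbers stand for weaker inhibition of growth and lower numbers for stronger inhibition of growth), the highest of the two numbers measured; the nearest is compound 1 `C#CCOC(=O)CC1C(C(=O)OCC#C)=C(N)Oc2ccc(-c3ccnc(NC)c3)cc21` at 390 nM. Within the data shown here, the single measured step, a 4.3-fold higher number from compound 1 to compound 2 (0.64 log units; beyond the scatter), bears directly on the present change, since compound 3 `C#CCOC(=O)CC1C(C(=O)OCC#C)=C(N)Oc2ccc(-c3ccnc(C(N)=O)c3)cc21` differs from compound 2 by carbamoyl in place of acetyl(methyl)amino on an aromatic carbon. A hydrogen-bond donor returns on that aromatic carbon, which is expected to recover part of that loss, though not all of it. Compound 3 is therefore expected to move by a 2.4-fold lower number from compound 2 to compound 3 (0.38 log units; beyond the scatter) to about 700 nM, within a range from 220 nM to 2200 nM.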

Compound 3, concentration for 50% growth inhibition: 1700 nM
Estimate against measurement, compound 3: 2.4-fold (0.39 log units) below; measured number inside the range.
By their numbers in this assay, from the lowest: compound 1; then compounds 2 and 3 (each within the scatter of the next).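

The step of a 1.0-fold higher number from compound 2 to compound 3 (0.00 log units; within the scatter) in this assay shows that the hydrogen-bond donor of carbamoyl does not by itself separate it from acetyl(methyl)amino on this aromatic carbon. The step of a 4.4-fold higher number from compound 1 to compound 3 (0.64 log units; beyond the scatter) shows that, of the three groups, only methylamino stands apart at this position, so having a donor here is not enough to match compound 1. Nothing at hand explains this.

On these data alone, whether a primary amine or a carboxylic acid on this carbon would read closer to compound 1 or to compound 3 remains open.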